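From 3,5-Difluorophenyl to 3-Chlorophenyl

A few compounds are considered here, and "the series" means these few. Any claim that something is new, unique, unknown or untested is made for them only; others in the source may bear on it.

In a functional assay on HL-60 cells (Homo sapiens) for inhibition, read by MTT assay, with a stated time of 72 h (a lower number here means a stronger inhibitor, a higher number a weaker inhibitor), compound 1 (`CCc1nc(-c2ccccc2F)c(C(=O)N2CCN(c3cccc(Cl)c3)CC2)o1`) gives 139 nM as its half-maximal inhibitory concentration, compound 2 (`Cc1nc(-c2ccccc2F)c(C(=O)N2CCN(c3cc(Cl)cc(Cl)c3)CC2)o1`) gives 60.2 nM and compound 3 (`Cc1nc(-c2ccccc2F)c(C(=O)N2CCN(c3cc(F)cc(F)c3)CC2)o1`) gives 186 nM on the same read-out. Compound 3 thus stands level with compound 1 within the scatter and clearly apart from compound 2. Compound 4 (`Cc1nc(-c2ccccc2F)c(C(=O)N2CCN(c3cccc(Cl)c3)CC2)o1`) is still unmeasured. It keeps the core of compound 3 but has 3-chlorophenyl in place of 3,5-difluorophenyl on an amine nitrogen in a ring. The closest evidence is a 3.1-fold higher number from compound 2 to compound 3 (0.49 log units; beyond the scatter) for the swap of 3,5-dichlorophenyl to 3,5-difluorophenyl, a modest step beyond the scatter. Compound 1 also carries 3-chlorophenyl on a slightly different core and gives 139 nM there. Neither comparison measures this exact change, so only a small move towards a lower number is expected. The estimated size is a 1.6-fold lower number from compound 3 to compound 4 (0.21 log units; within the scatter) in this assay and may stay within the scatter. Compound 4 is expected near 115 nM with a likely range from 55 nM to 240 nM for this estimate.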

Compound 4, half-maximal inhibitory concentration: 39.4 nM
Compound 4: middle estimate off by 2.9-fold (0.47 log units), on the high side; measured number below the stated range.
By their numbers in this assay, from the lowest: compounds 4 and 2 (each within the scatter of the next); then compounds 1 and 3 (each within the scatter of the next).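

In this assay this position on the amine nitrogen proves sensitive to the choice of halogen: the swap to 3-chlorophenyl gives a 4.7-fold lower number from compound 3 to compound 4 (0.67 log units; beyond the scatter), so the weaker result with 3,5-difluorophenyl is not simply a feature of the shared core. A second chloro adds nothing that can be told apart, since a 1.5-fold lower number from compound 2 to compound 4 (0.18 log units; within the scatter) stays within the usual scatter. The position is also not the only one that counts, as shortening the ethyl chain on the core to methyl gives a 3.5-fold lower number from compound 1 to compound 4 (0.55 log units; beyond the scatter), so compounds with the same 3-chlorophenyl group can still differ clearly.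

The data shown offer no explanation for any of these steps. Still open, going by these compounds, is how 3-fluorophenyl or 3-methoxyphenyl would compare with 3-chlorophenyl on the same core, which would help separate the effect of the atom from that of the number of substituents.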